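This account rests on a few compounds, and the source may have more. Where it says the series, first, only, none or still open, it means among the compounds named here.

Measured in an ADME assay on HEK293 cells (Homo sapiens) for cytotoxicity, read by MTT assay, with a stated time of 48 h; on this read-out lower numbers stand for stronger inhibition and higher numbers for weaker inhibition:
- compound 1 `CN(C)CCCn1c(N)c(-c2nc3ccccc3s2)c2nc(C#N)c(C#N)nc21`: 4290 nM
- compound 2 `CN(C)CCCn1c(N)c(-c2nc3ccccc3n2C)c2nc(C#N)c(C#N)nc21`: 8410 nM
- compound 3 `CCN(CC)CCn1c(N)c(-c2nc3cc(Cl)ccc3[nH]2)c2nc(C#N)c(C#N)nc21`: > 50000 nM

Compound 3 stands at > 50000 nM, which is a limit of the assay and not a number.

Compound 4 `CN(C)CCCn1c(N)c(-c2nc3cc(Cl)ccc3[nH]2)c2nc(C#N)c(C#N)nc21` is still to be measured in this assay. It differs from compound 3 only in the side chain: (dimethylamino)methyl in place of diethylamino on a saturated chain carbon, two bonds along the chain from an aromatic nitrogen. Cut one bond further out, the same difference reads 2-(diethylamino)ethyl to 3-(dimethylamino)propyl.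

Among the measured compounds shown here, no measured step covers this change. For the measured compounds named here, the only measured step, a 2.0-fold higher number from compound 1 to compound 2 (0.29 log units; within the scatter), is 1-methyl-1H-benzimidazol-2-yl in place of 1,3-benzothiazol-2-yl on an aromatic carbon, so it bears only indirectly. It does show that this aromatic group changed with no effect beyond the scatter while the 3-(dimethylamino)propyl chain stayed in place. That chain gives a measured number in both compounds that carry it, compound 1 at 4290 nM and compound 2 at 8410 nM. On these two compounds alone, a move towards lower numbers, meaning stronger inhibition, is expected for the chain change, with its size uncertain. The expected step is an at least 3.3-fold lower number from compound 3 to compound 4 (0.52 log units; beyond the scatter). For compound 4 the estimated value is 15000 nM, with an expected range of 4000 nM to 45000 nM.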

Compound 4, half-maximal inhibitory concentration: 11700 nM
For compound 4 the middle estimate is 1.3-fold (0.11 log units) above the measured one; low and high end bracket the measured number.
By their numbers in this assay, from the lowest: compounds 1, 2 and 4 (each within the scatter of the next, the first and the last beyond it). At a limit, above all of these: compound 3.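

In this assay, with the 5-chloro-1H-benzimidazol-2-yl group held constant, going from 2-(diethylamino)ethyl to 3-(dimethylamino)propyl gives an at least 4.2-fold lower number from compound 3 to compound 4 (0.63 log units; beyond the scatter), so the side chain alone moves the read-out from a limit to a measured number. The size of this step has only a lower bound, since compound 3 stands at a limit of the assay and not at a number: the limit of > 50000 nM in this assay, at which 1 of the 4 values shown sits. Among the compounds shown here, with the 3-(dimethylamino)propyl chain kept in place, the aromatic group can now be compared across three compounds: a 1.4-fold higher number from compound 2 to compound 4 (0.14 log units; within the scatter), while a 2.7-fold higher number from compound 1 to compound 4 (0.44 log units; beyond the scatter), which makes 5-chloro-1H-benzimidazol-2-yl in place of 1,3-benzothiazol-2-yl the only aromatic change here that lies beyond the scatter.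

The compounds shown leave open whether the chain step belongs to the longer chain or to the dimethylamino end, and a 3-(diethylamino)propyl or a 2-(dimethylamino)ethyl chain on the same 5-chloro-1H-benzimidazol-2-yl compound would separate the two. Also open, from the compounds shown here alone, is how a morpholine or a primary amine at the chain end would read in this assay.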